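Ethynyl substituent variants: three measured, cyclohexyl analogue pending

The source may report more compounds than this note shows. Statements on the series, on what has been measured and on what is new or still open speak of the compounds shown alone.

Measured compounds:
compound 1 `CNC(=O)[C@@]12C[C@@H]1[C@@H](n1cnc3c(NC)nc(C#Cc4ccc(F)c(F)c4)nc31)[C@H](O)[C@@H]2O` — 86 nM
compound 2 `CNC(=O)[C@@]12C[C@@H]1[C@@H](n1cnc3c(NC)nc(C#Cc4ncccn4)nc31)[C@H](O)[C@@H]2O` — 65 nM
compound 3 `CNC(=O)[C@@]12C[C@@H]1[C@@H](n1cnc3c(NC)nc(C#Cc4cccnn4)nc31)[C@H](O)[C@@H]2O` — 112 nM

All three numbers come from an assay on HEK293 cells for displacement of a labelled ligand from adenosine receptor A3 (Mus musculus), read by scintillation counting, with a stated time of 60 min; a higher number here means a weaker inhibitor, a lower number a stronger inhibitor. Compound 2 stands at the lowest of the three, but every step among them lies within the scatter: a 1.3-fold lower number from compound 1 to compound 2 (0.12 log units; within the scatter), a 1.3-fold higher number from compound 1 to compound 3 (0.11 log units; within the scatter) and a 1.7-fold higher number from compound 2 to compound 3 (0.24 log units; within the scatter). The pending compound 4 `CNC(=O)[C@@]12C[C@@H]1[C@@H](n1cnc3c(NC)nc(C#CC4CCCCC4)nc31)[C@H](O)[C@@H]2O` differs from compound 2 by cyclohexyl in place of pyrimidin-2-yl on a triple-bonded carbon. Among the compounds with values here, no measured step bears directly on this change: each measured step exchanges one six-membered aromatic ring for another, whereas here a non-aromatic ring of carbon only enters. With nothing beyond the scatter among the measured steps, no step beyond the scatter is expected for compound 4 either, so the expected step is a 1.5-fold higher number from compound 2 to compound 4 (0.19 log units; within the scatter). On these data alone, compound 4 is therefore estimated at 100 nM, with a range from 30 nM to 350 nM; the range is wide, as the change is untested.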

Compound 4, inhibition constant: 40.9 nM
Beside the measured number, compound 4's estimate is 2.4-fold (0.39 log units) above it; the measured number falls inside the stated range.
By their numbers in this assay, from the lowest: compounds 4, 2, 1 and 3 (each within the scatter of the next, the first and the last beyond it).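

In this assay, cyclohexyl on the triple-bonded carbon gives a 1.6-fold lower number from compound 2 to compound 4 (0.20 log units; within the scatter), so a non-aromatic ring of carbon only is accepted here. Against the other two rings, the change gives the first steps in the series beyond the scatter, though both are modest: a 2.1-fold lower number from compound 1 to compound 4 (0.32 log units; beyond the scatter) and a 2.7-fold lower number from compound 3 to compound 4 (0.44 log units; beyond the scatter). Nothing available explains these steps.

On these data alone, whether a ring is needed at all on the triple-bonded carbon remains open, as a longer alkyl chain there would show. Also open, as far as these compounds go, is whether an amine or a carboxylic acid on the cyclohexyl ring would be accepted.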